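Aryl hydrazone swap at the imine carbon of compound 2

The compounds below may be only part of what the source reports. "The series", "measured", "known", "first", "only" and "open" are said of these compounds alone.

Measured compounds:
compound 1 `COc1ccc(/C=N/NC(=O)Nc2ccc(Oc3ccnc4cc(OCCCN5CCCCC5)c(OC)cc34)c(F)c2)c(OC)c1`, 1600 nM
compound 2 `COc1cc2c(Oc3ccc(NC(=O)N/N=C/c4ccncc4)cc3F)ccnc2cc1OCCCN1CCCCC1`, 940 nM

Both compounds were tested in a functional assay on HT-29 cells (Homo sapiens) for cytotoxicity, read by MTT assay, with a stated time of 72 h; a higher number here means a weaker inhibitor, a lower number a stronger inhibitor. Compound 1 gives 1600 nM, and compound 2 gives 940 nM. The step of a 1.7-fold lower number from compound 1 to compound 2 (0.23 log units; within the scatter) came with a pyridin-4-yl in place of a 2,4-dimethoxyphenyl on the carbon with a double bond to nitrogen. Compound 2 thus holds the lowest of the two numbers, but its separation from compound 1 falls within the scatter, so no order between them can be claimed.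

Compound 3 `COc1cc2c(Oc3ccc(NC(=O)N/N=C/c4cccs4)cc3F)ccnc2cc1OCCCN1CCCCC1` continues from compound 2 with the change (thiophen-2-yl in place of pyridin-4-yl on a carbon with a double bond to nitrogen). For the measured compounds named here, the only step that bears on it is the aryl swap at the same carbon, which was small. Because a 1.7-fold lower number from compound 1 to compound 2 (0.23 log units; within the scatter) stayed within the scatter, an exchange of one small aromatic ring for another at this carbon is expected to move this assay by little if at all, with no clear direction. For compound 3 the estimate is 1100 nM, ranging from 400 nM to 3200 nM. The expected step is a 1.2-fold higher number from compound 2 to compound 3 (0.07 log units; within the scatter).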

Compound 3, half-maximal inhibitory concentration: 770 nM
For compound 3 the middle estimate is 1.4-fold (0.15 log units) above the measured one; the range from low to high includes it.
By their numbers in this assay, from the lowest: compounds 3, 2 and 1 (each within the scatter of the next, the first and the last beyond it).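

In this assay, the exchange of pyridin-4-yl for thiophen-2-yl on the carbon with a double bond to nitrogen gave a 1.2-fold lower number from compound 2 to compound 3 (0.09 log units; within the scatter) and so did not separate the five-membered sulfur ring from the six-membered nitrogen ring. For the compounds shown here, the result does add the first step at this carbon to lie beyond the scatter, a 2.1-fold lower number from compound 1 to compound 3 (0.32 log units; beyond the scatter) with thiophen-2-yl in place of 2,4-dimethoxyphenyl, although this step is modest and compound 2 lies within the scatter of both compound 1 and compound 3. No supporting data bear on why these three aryl groups give such close numbers.

The compounds shown carry only aromatic rings at this carbon, so it remains open whether a saturated ring such as piperidin-4-yl, a short alkyl chain bearing an amine, or an aryl group carrying a carboxylic acid would give a larger step. From the compounds shown here alone, it is also open whether the thiophene sulfur matters at all, which furan-2-yl or thiophen-3-yl at the same carbon could test.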